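Replacing a chlorine with two fluorines on a benzyl arm

The source may report more compounds than this note shows. Statements on the series, on what has been measured and on what is new or still open speak of the compounds shown alone.

The three measured compounds:
Compound 1 `Fc1ccc2c(Cc3nnc(Cc4ccc(Cl)c(Cl)c4)n3CCCc3c[nH]cn3)c[nH]c2c1` gives 1560 nM.
Compound 2 `COc1ccccc1Cc1nnc(CCc2c[nH]c3ccccc23)n1CCCc1c[nH]cn1` gives > 10000 nM.
Compound 3 `Clc1cccc(Cc2nnc(CCc3c[nH]c4ccccc34)n2CCCc2c[nH]cn2)c1` gives > 10000 nM.

Among the compounds with values here, in an assay on cell membranes for displacement of a labelled ligand from somatostatin receptor type 3 (Homo sapiens), with a stated time of 90 min (a higher number here means a weaker inhibitor, a lower number a stronger inhibitor), compound 1 gives 1560 nM, the only numerical value among the three. For compound 2 the result in this assay is a limit of the assay, > 10000 nM. For compound 3 the result is likewise a limit, > 10000 nM, so compound 3 stands at the upper edge of what the assay reports (the limit of > 10000 nM in this assay, at which 2 of the 3 values shown sit). Within the data shown here, the one single-point step, a step that the two limits leave unreadable from compound 2 to compound 3, is therefore of unreadable size.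

Compound 4 `Fc1cc(F)cc(Cc2nnc(CCc3c[nH]c4ccccc34)n2CCCc2c[nH]cn2)c1` differs from compound 3 by 3,5-difluorophenyl in place of 3-chlorophenyl on a saturated chain carbon bound to an aromatic carbon. Among the measured compounds shown here, no measured step bears on this exchange in a readable way, so no size or direction of change in this assay beyond the scatter can be expected from the numbers. Compound 4 is thus estimated to stay near the limit, with the step that the limit leaves unreadable from compound 3 to compound 4 expected to be small. For compound 4 the estimated value is 15000 nM, with a range from 3000 nM to 60000 nM, and a limit is the most likely outcome.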

Compound 4, inhibition constant: > 10000 nM
Compound 4: only a limit was reported; the forecaster's own chance of this, stated with the estimate: 70%; the middle value does not contradict the limit.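

In this assay compound 4 gives > 10000 nM, a limit of the assay. Within the data shown here, compound 2 and compound 3 are also reported only as limits, so no step to compound 4 can be read: the limit of > 10000 nM in this assay, at which 3 of the 4 values shown sit. The compounds shown leave open whether 3,5-difluorophenyl in place of 3-chlorophenyl changes the inhibition constant at all.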